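Methyl for isopropyl on the propargylic ether series

This account rests on a few compounds, and the source may have more. Where it says the series, first, only, none or still open, it means among the compounds named here.

Measured compounds:
compound 1, `CCC(C#CC(=O)OC)O/C=C/C(=O)OC`, in a functional assay on HBL-100 cells (Homo sapiens) for antiproliferative activity, read by sulforhodamine B assay, with a stated time of 48 h (on this read-out higher numbers stand for weaker inhibition of growth and lower numbers for stronger inhibition of growth), compound 1 gives 320 nM.
compound 2, `COC(=O)C#CC(CC(C)C)O/C=C/C(=O)OC`, in this assay compound 2 gives 330 nM.
compound 3, `COC(=O)C#CC(O/C=C/C(=O)OC)C(C)C`, in this assay compound 3 gives 450 nM.

The three measured compounds share the same core and differ only in the substituent on the saturated chain carbon bound to an oxygen on an unsaturated carbon and a triple-bonded carbon. All three numbers fall close together: a 1.0-fold lower number from compound 2 to compound 1 (0.01 log units; within the scatter), a 1.4-fold higher number from compound 1 to compound 3 (0.15 log units; within the scatter) and a 1.4-fold higher number from compound 2 to compound 3 (0.13 log units; within the scatter), each within the scatter, so no ordering among compound 1, compound 2 and compound 3 can be read from these data.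

Compound 4, `COC(=O)C#CC(C)O/C=C/C(=O)OC`, is not yet measured. It differs from compound 3 by methyl in place of isopropyl on a saturated chain carbon bound to an oxygen on an unsaturated carbon and a triple-bonded carbon. The same kind of change has already been made once, from compound 2 to compound 1, where it reads (methyl in place of isopropyl on a saturated chain carbon, two bonds along the chain from an oxygen on an unsaturated carbon and a triple-bonded carbon); there the step was a 1.0-fold lower number from compound 2 to compound 1 (0.01 log units; within the scatter). The two places are not identical: in the measured pair the methyl enters on a saturated chain carbon two bonds along the chain from an oxygen on an unsaturated carbon and a triple-bonded carbon, whereas in compound 4 it enters on the saturated chain carbon bound directly to that oxygen and triple-bonded carbon. The cores of compound 2 and compound 3 differ by isopropyl in place of isobutyl on a saturated chain carbon bound to an oxygen on an unsaturated carbon and a triple-bonded carbon.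

Given that the earlier methyl-for-isopropyl step was flat, and that every step among the measured compounds is within the scatter, compound 4 is expected to give a number close to that of compound 3 in this assay, an expected step of a 1.0-fold lower number from compound 3 to compound 4 (0.02 log units; within the scatter). The estimate for compound 4 in this assay is 430 nM, expected to lie between 200 nM and 950 nM.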

Compound 4, concentration for 50% growth inhibition: 300 nM
Estimate against measurement, compound 4: 1.4-fold (0.16 log units) above; measured number inside the range.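

Methyl in place of isopropyl can now be read on two cores in this assay, and the two readings do not differ: the same change on two cores in this assay, a 1.0-fold lower number (0.01 log units; within the scatter) from compound 2 to compound 1 and a 1.5-fold lower number (0.18 log units; within the scatter) from compound 3 to compound 4, 1.5-fold (0.16 log units) apart, within the scatter of two such steps. On the core of compound 3 the step is a 1.5-fold lower number from compound 3 to compound 4 (0.18 log units; within the scatter), and the other two new steps, a 1.1-fold lower number from compound 2 to compound 4 (0.04 log units; within the scatter) and a 1.1-fold lower number from compound 1 to compound 4 (0.03 log units; within the scatter), are likewise within the scatter, so on these two cores the change leaves no readable mark on growth inhibition. This shows that a flat step on one core was matched by a flat step on the other, but it gives no ordering among the four compounds and does not show that the change would stay flat on any further core.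

On these data alone, all four compounds carry only saturated alkyl groups on the saturated chain carbon bound to an oxygen on an unsaturated carbon and a triple-bonded carbon, so the response to a longer chain, a phenyl ring, an amine or a carboxylic acid at that place remains open. As far as these compounds go, both methyl esters stay the same throughout, and so what happens when either is replaced, for example by an amide or a free carboxylic acid, also remains open.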